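Removing an Acetyl Group: From Compound 1 to Compound 4

A few compounds are considered here, and "the series" means these few. Any claim that something is new, unique, unknown or untested is made for them only; others in the source may bear on it.

Three small ureas built on a shared core have been tested in a functional assay on L1210 cells (Mus musculus) for inhibition, read by MTT assay; on this read-out higher numbers stand for weaker inhibition and lower numbers for stronger inhibition. Compound 1 `CC(=O)c1cccc(NC(=O)N2CC2C#N)c1` gives 7900 nM. Compound 2 `N#CC1CN1C(=O)Nc1cccnc1` gives 16000 nM, and compound 3 `CNC(=O)N1CC1C#N`, which carries only a methyl group on the urea nitrogen, gives 21000 nM. Among these three numbers compound 1 stands lowest, and so is the strongest inhibitor here: its nearest neighbour is compound 2, whose number is beyond the scatter above it, and compound 3 sits further still.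

Compound 4 `N#CC1CN1C(=O)Nc1ccccc1` has not yet been measured. It differs from compound 1 in one place: hydrogen in place of acetyl on an aromatic carbon. The acetyl group that sits on the aromatic ring of compound 1 is simply gone, leaving a bare ring on the urea nitrogen.

Among the compounds with values here, no measured pair shows the effect of this change directly, so the expectation rests on the spread of the three values. A modest weakening of inhibition is expected, of a size that may well stay within the scatter, because compound 2 gives 16000 nM while compound 3 gives 21000 nM. Compound 4 is therefore estimated to give 12000 nM, with a range from 5000 nM to 30000 nM, meaning an expected step of a 1.5-fold higher number from compound 1 to compound 4 (0.18 log units; within the scatter).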

Compound 4, half-maximal inhibitory concentration: 11000 nM
Beside the measured number, compound 4's estimate is 1.1-fold (0.04 log units) above it, within the range that was stated.
By their numbers in this assay, from the lowest: compounds 1, 4, 2 and 3 (each within the scatter of the next, the first and the last beyond it).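

In this assay, replacing the acetyl group with hydrogen on this aromatic carbon gives a 1.4-fold higher number from compound 1 to compound 4 (0.14 log units; within the scatter), so the two compounds cannot be told apart on this read-out. This is the first pair shown that differs in one place only, and it indicates that the acetyl group, with its three heavy atoms and its hydrogen-bond acceptor, is not required at this position for the level of inhibition seen in compound 1. Nothing shown here explains why this change makes so little difference.

The compounds shown leave open whether any other group on this same aromatic carbon, such as an amine or a carboxylic acid, would move the number beyond the scatter in either direction, since a single replacement by hydrogen says little about what a different group would do there. They also leave open whether a longer chain in place of the acetyl group would be tolerated as well, or whether the same group placed elsewhere on the ring would give a similar result.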